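A few compounds are considered here, and "the series" means these few. Any claim that something is new, unique, unknown or untested is made for them only; others in the source may bear on it.

Measured in a toxicity assay on HT-29 cells (Homo sapiens) for cytotoxicity; on this read-out lower numbers stand for higher toxicity in this test and higher numbers for lower toxicity in this test:
- compound 1 `CN1C(=S)[C@@H](NC(=O)c2nc(Cc3ccccc3)n(C)n2)COc2ccccc21`: > 100000 nM (a limit)
- compound 2 `CN1C(=S)[C@@H](NC(=O)c2nc(Cc3ccccc3)n(CCCC(F)(F)F)n2)COc2ccccc21`: > 100000 nM (a limit)

Compound 2 stands only at a limit, > 100000 nM, in this assay. Among the measured compounds shown here, the one other value, that of compound 1, is also a limit and not a number.

Compound 3 `CN1C(=S)[C@@H](NC(=O)c2nc(Cc3ccccc3)n(CCCCC#N)n2)COc2ccccc21` is still unmeasured. It differs from compound 2 by cyanomethyl in place of trifluoromethyl on a saturated chain carbon, three bonds along the chain from an aromatic nitrogen. In words, cyanomethyl takes the place of trifluoromethyl on a saturated chain carbon, three bonds along the chain from an aromatic nitrogen, so that 4,4,4-trifluorobutyl becomes 4-cyanobutyl.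

For the measured compounds named here, the only measured step that bears on this change is a step that the two limits leave unreadable from compound 1 to compound 2. It offers no size to carry over. What the data do show is the limit of > 100000 nM in this assay, at which 2 of the 2 values shown sit. No step beyond the usual scatter is therefore expected in this assay, in either direction, and a further report of the limit is the likeliest outcome.

The expected step is a number no higher from compound 2 to compound 3 (the limit leaves the size open). For compound 3 the estimated value is 100000 nM, with an expected range from 30000 nM to 100000 nM.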

Compound 3, half-maximal cytotoxic concentration: > 100000 nM
Compound 3: only a limit was reported (the forecaster's own chance of this, stated with the estimate: 85%); the middle value lies on the limit itself.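

Among the compounds shown here, compound 3, like compound 1 and compound 2, is reported only as a limit in this assay, so no step among the three can be read. The result adds one more entry to what was already seen: the limit of > 100000 nM in this assay, at which 3 of the 3 values shown sit.

The compounds shown leave open whether these side chains differ at all in toxicity on the shared core, since none of them gives a number.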